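Fluorine placement on a stilbene-like core and reporter activation

A few compounds are considered here, and "the series" means these few. Any claim that something is new, unique, unknown or untested is made for them only; others in the source may bear on it.

Compound 1, `Fc1ccccc1/C=C/c1ccccc1F`, carries two fluoro groups on a shared core of two carbon rings joined through a two-carbon double bond. In an assay on HepG2 cells for activation of nuclear factor erythroid 2-related factor 2 (Homo sapiens), read by a luciferase reporter, with a stated time of 5 h (on this read-out higher numbers stand for an effect only at larger amounts of compound and lower numbers for an effect already at smaller amounts), compound 1 gives 4300 nM. Compound 2, `Fc1ccc(F)c(/C=C/c2ccccc2F)c1`, adds one more fluoro group and in this assay gives 5900 nM; the change is fluoro in place of hydrogen on an aromatic carbon, and the measured step is a 1.4-fold higher number from compound 1 to compound 2 (0.14 log units; within the scatter).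

Compound 3, `Fc1ccc(/C=C/c2cccc(F)c2)cc1`, has the same atoms as compound 1 but joined in a different arrangement; the difference between the two cores is not broken down here. In this assay compound 3 gives 650 nM, the lowest number of the three measured compounds, with steps to compound 1 and to compound 2 that both lie beyond the scatter.

Compound 4, `Fc1ccc(/C=C/c2cc(F)ccc2F)cc1`, is not yet measured. It arises from compound 3 by fluoro in place of hydrogen on an aromatic carbon. Within the data shown here, this is the same kind of change as the one from compound 1 to compound 2, but not the same: in that earlier pair the entering fluoro sits meta to the group of 9 heavy atoms, whereas here it sits ortho to that group, while in both cases it is para to a fluoro group. Among the measured compounds shown here, the only measured example of this kind of change gave a step within the scatter, so for compound 4 a step of about a 1.4-fold higher number from compound 3 to compound 4 (0.14 log units; within the scatter) is expected, resting on that earlier result. Compound 4 is therefore estimated to give 900 nM in this assay, with a likely range from 400 nM to 2200 nM.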

Compound 4, half-maximal effective concentration: 2900 nM
Estimate against measurement, compound 4: 3.2-fold (0.51 log units) below; measured number above the stated range.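

In this assay, fluoro in place of hydrogen on an aromatic carbon gives a 4.5-fold higher number from compound 3 to compound 4 (0.65 log units; beyond the scatter), which is a clear step on this core. Set beside the earlier result, the same change does not give the same size of step on the two cores: the same change on two cores in this assay, a 1.4-fold higher number (0.14 log units; within the scatter) from compound 1 to compound 2 and a 4.5-fold higher number (0.65 log units; beyond the scatter) from compound 3 to compound 4, 3.3-fold (0.51 log units) apart, beyond the scatter of two such steps. Among these compounds, this shows that, in this series, the step seen on one core cannot simply be carried over to the other, but with only two pairs it does not show what sets the size of the step, as the cores differ and the entering fluoro may also stand differently in each pair, here ortho to a group of 9 heavy atoms and para to a fluoro group.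

The compounds shown carry nothing but fluoro groups on their rings, so it remains open how a different group at this same place, such as a methoxy group, an amine or a carboxylic acid, would change the number. From the compounds shown here alone, it also remains open whether this change on a further core would give a step like the smaller one, like the larger one, or something else.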